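Working notes: from compound 2 to compound 3

The source may report more compounds than this note shows. Statements on the series, on what has been measured and on what is new or still open speak of the compounds shown alone.

Compound 1 `Cc1ccc(C(=O)O[C@@H]2C[C@H](C)CC[C@H]2C(C)C)cc1`: 5.29
Compound 2 `CC(C)[C@@H]1CC[C@@H](C)C[C@H]1OC(=O)c1ccccc1`: 4.82

In a physicochemical assay for lipophilicity, measured as octanol-water partition (on this read-out higher numbers stand for higher lipophilicity and lower numbers for lower lipophilicity), compound 2 holds the lower of the two measured numbers at 4.82, under compound 1 at 5.29. Compound 3 `CC(Cl)C(=O)O[C@@H]1C[C@H](C)CC[C@H]1C(C)C` is the next to be read, and its structural change from compound 2 is 1-chloroethyl in place of phenyl on a carbonyl carbon.

Going by the values given here, only one measured step bears on this, a number 0.47 log units lower from compound 1 to compound 2 (beyond the scatter), for hydrogen in place of methyl on an aromatic carbon. Among the compounds with values here, it is a much smaller edit, and no measured step replaces the phenyl itself, so the guide is weak. A downward step larger than that one is expected in this assay.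

The estimated change is a number 0.72 log units lower from compound 2 to compound 3 (beyond the scatter).

For compound 3 the expected value is 4.1, with an estimated range of 3.6 to 4.6.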

Compound 3, partition coefficient: 4.04
Compound 3: middle estimate off by 0.06 log units, on the high side; the measured number falls inside the stated range.
By their numbers in this assay, from the lowest: compound 3; then compound 2; then compound 1.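

In this assay the group on the carbonyl carbon is open to replacement with a change beyond the scatter (a number 0.78 log units lower from compound 2 to compound 3 (beyond the scatter)), as phenyl leaves and 1-chloroethyl enters. The earlier step (a number 0.47 log units lower from compound 1 to compound 2 (beyond the scatter)) only trimmed a methyl from an aromatic carbon and kept the ring, whereas this one removes the ring from that place altogether and shows that the series still reads on the same scale without it. Nothing at hand accounts for the size of this step.

Phenyl leaves and chlorine enters in a single step, so the compounds shown cannot divide the change between the two. An ethyl group on the same carbonyl carbon would separate them, and a longer chain or an amine at that place remains an open question.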